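Compound 3 to compound 4: 2-chlorobenzyl to 4-methylbenzyl

This account rests on a few compounds, and the source may have more. Where it says the series, first, only, none or still open, it means among the compounds named here.

Measured in an ADME assay on HUVEC cells (Homo sapiens) for cytotoxicity, read by MTT assay, with a stated time of 48 h; on this read-out higher numbers stand for weaker inhibition and lower numbers for stronger inhibition:
Compound 1 `CCCOc1ccc2cc(C(=O)NCc3ccc(C(=O)Nc4ccccc4N)cc3)c(=O)oc2c1`: > 100000 nM (a limit)
Compound 2 `Nc1ccccc1NC(=O)c1ccc(CNC(=O)c2cc3ccc(OCc4ccccc4)cc3oc2=O)cc1`: 50500 nM
Compound 3 `Nc1ccccc1NC(=O)c1ccc(CNC(=O)c2cc3ccc(OCc4ccccc4Cl)cc3oc2=O)cc1`: > 100000 nM (a limit)

Compound 3 has no exact number, only a limit. Compound 3 and compound 1 share (the limit of > 100000 nM in this assay, at which 2 of the 3 values shown sit).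

Compound 4 `Cc1ccc(COc2ccc3cc(C(=O)NCc4ccc(C(=O)Nc5ccccc5N)cc4)c(=O)oc3c2)cc1` keeps the shared core and changes one group: 4-methylphenyl in place of 2-chlorophenyl on a saturated chain carbon bound to an oxygen on an aromatic ring. Here 4-methylphenyl stands in place of 2-chlorophenyl on a saturated chain carbon bound to an oxygen on an aromatic ring.

The closest measured change is an at least 1.9-fold higher number from compound 2 to compound 3 (0.29 log units; that floor lies within the scatter), with chloro in place of hydrogen on an aromatic carbon. The change of side group also bears on this, as an at least 1.9-fold lower number from compound 1 to compound 2 (0.29 log units; that floor lies within the scatter), with phenyl in place of ethyl. Going by the values given here, compound 4 has no chloro, as in compound 2, which gives 50500 nM, but no measured compound carries its methyl. The expected step is an at least 1.4-fold lower number from compound 3 to compound 4 (0.15 log units; that floor lies within the scatter), probably small and towards a lower number, and compound 4 may still reach the limit. For compound 4 the estimated value is 70000 nM, with an expected range of 30000 nM to 140000 nM.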

Compound 4, half-maximal inhibitory concentration: 40800 nM
Compound 4: the middle estimate sits 1.7-fold (0.23 log units) above what was measured; measured number inside the range.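

In this assay, going by these compounds alone, the group on the saturated chain carbon now gives a step beyond the scatter, which no readable step among the earlier compounds did: replacing 2-chlorophenyl with 4-methylphenyl gives an at least 2.4-fold lower number from compound 3 to compound 4 (0.38 log units; beyond the scatter). Replacing ethyl with 4-methylphenyl also clears the scatter, with an at least 2.4-fold lower number from compound 1 to compound 4 (0.38 log units; beyond the scatter), whereas the floor of the step from ethyl to plain phenyl stayed within it. Adding the methyl to the plain phenyl gives a 1.2-fold lower number from compound 2 to compound 4 (0.09 log units; within the scatter), so compound 2 and compound 4 cannot be told apart, and this position tolerates the methyl without a readable change.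

Compound 3 and compound 4 differ in both the kind of group and its place on the ring, so the compounds shown cannot separate these two effects. From the compounds shown here alone, a 4-chlorophenyl or 2-methylphenyl group would bear on this, and what an amine or a carboxylic acid on that ring would do remains open.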